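Working notes: a fluoroalkyl change in the series

The compounds below may be only part of what the source reports. "The series", "measured", "known", "first", "only" and "open" are said of these compounds alone.

Measured in an ADME assay, at pH 3 (on this read-out lower numbers stand for a shorter-lived compound and higher numbers for a longer-lived compound), so far:
- compound 1 `COc1ccnc(C[S+]([O-])c2nc3cc(OCC(F)(F)F)ccc3[nH]2)c1OC` gives 0.183 h
- compound 2 `COc1cnc(C[S+]([O-])c2nc3cc(OCC(F)(F)F)ccc3[nH]2)c(C)c1OC` gives 0.167 h
- compound 3 `COc1ccnc(C[S+]([O-])c2nc3cc(OCC(F)(F)F)ccc3[nH]2)c1C` gives 0.0833 h

Compound 1 and compound 2 lie within the scatter of each other. Compound 3 is separated from compound 1 by a modest step beyond the scatter, seen as a 2.2-fold lower number from compound 1 to compound 3 (0.34 log units; beyond the scatter) in the same series. The other measured step, a 2.0-fold lower number from compound 2 to compound 3 (0.30 log units; within the scatter), stays within the scatter.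

Compound 4 `COc1ccnc(C[S+]([O-])c2nc3cc(OC(F)(F)C(F)F)ccc3[nH]2)c1OC` has not yet been measured. It differs from compound 1 in one place: 1,1,2,2-tetrafluoroethyl in place of 2,2,2-trifluoroethyl on an oxygen on an aromatic ring here. The change is 1,1,2,2-tetrafluoroethyl in place of 2,2,2-trifluoroethyl on an oxygen on an aromatic ring, and neither group carries a ring or a net charge.

Neither measured step touches this group, since both concern a substituent on an aromatic carbon. They show only how far a single change has moved the number in this series, and they give no direction for the new change. No step beyond the scatter is therefore expected in this assay for this change. The expected step is a 1.2-fold higher number from compound 1 to compound 4 (0.08 log units; within the scatter) in size.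

For compound 4 the estimated half-life is 0.22 h in this read-out. The estimated range for compound 4 runs from 0.11 h to 0.45 h as the likely span.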

Compound 4, half-life: 0.3 h
For compound 4 the middle estimate is 1.4-fold (0.13 log units) below the measured one, and the stated range covers the measured number.
By their numbers in this assay, from the lowest: compounds 3, 2, 1 and 4 (each within the scatter of the next, the first and the last beyond it).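

At the group on an oxygen on an aromatic ring, this assay gives a 1.6-fold higher number from compound 1 to compound 4 (0.21 log units; within the scatter) and so does not separate 1,1,2,2-tetrafluoroethyl from 2,2,2-trifluoroethyl on this read-out. Going by these compounds alone, both earlier steps concerned substituents on an aromatic carbon, whereas this pair is the first to probe the fluoroalkyl group, and in this one pair the exchange leaves compound 4 within the scatter of compound 1. Nothing shown here bears on why the number of compound 4 falls where it does, and the step is therefore recorded without any explanation.

As far as these compounds go, the reading rests on a single pair on the core of compound 1, so whether the same exchange would stay within the scatter on the cores of compound 2 and compound 3 remains open. Also open is how this assay would read with a plain ethyl group, a longer fluoroalkyl chain or a chain carrying an amine on the same oxygen, as every group shown at this place is a two-carbon fluoroalkyl group.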